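A few compounds are considered here, and "the series" means these few. Any claim that something is new, unique, unknown or untested is made for them only; others in the source may bear on it.

Measured so far in a functional assay on muscle tissue (Mustela putorius furo); on this read-out lower numbers stand for smaller maximal responses and higher numbers for larger maximal responses: compound 1 `OC(CSc1ncnc2[nH]cnc12)CN1CCN(C(c2ccc(F)cc2)c2ccc(F)cc2)CC1` gives 189%; compound 2 `Cn1cnc2c(SCC(O)CN3CCN(C(c4ccc(F)cc4)c4ccc(F)cc4)CC3)ncnc21` gives 142%.

Among the measured compounds shown here, compound 2 stands lowest of the two numbers, the single measured step being a number 47 percentage points lower from compound 1 to compound 2 (beyond the scatter), a methyl in place of hydrogen on an aromatic nitrogen. Compound 3 `OC(CNc1[nH]cnc2ncnc1-2)CN1CCN(C(c2ccc(F)cc2)c2ccc(F)cc2)CC1` differs from compound 2 by a group of 10 heavy atoms (5 carbon, 5 nitrogen; one five-membered aromatic ring with 2 hetero atoms, one six-membered aromatic ring with 2 hetero atoms) in place of a group of 11 heavy atoms (6 carbon, 4 nitrogen, 1 sulfur; one five-membered aromatic ring with 2 hetero atoms, one six-membered aromatic ring with 2 hetero atoms), on a saturated chain carbon, two bonds along the chain from an oxygen on a saturated carbon. That one step concerns a different change and gives no direction here, so no step beyond the scatter is assumed, with a wide range. Compound 3 is estimated at 135% (range 85% to 190%). The implied step, a number 7 percentage points lower from compound 2 to compound 3 (within the scatter), is an expectation only.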

Compound 3, largest response reached (reported as maximum), in percent of the reference or control that the assay uses: 86%
Beside the measured number, compound 3's estimate is 49 percentage points above it; the range from low to high includes it.
By their numbers in this assay, from the lowest: compound 3; then compound 2; then compound 1.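

In this assay, the place on a saturated chain carbon, two bonds along the chain from an oxygen on a saturated carbon, now carries large steps of its own: a number 56 percentage points lower from compound 2 to compound 3 (beyond the scatter), and a number 103 percentage points lower from compound 1 to compound 3 (beyond the scatter). The group without sulfur thus gives the lowest maximal response of the set, whether compared with the methylated or the unmethylated sulfur-containing group. No measurement at hand explains this drop.

Still open, as far as these compounds go, is whether an ether oxygen in place of the sulfur would stay near compound 1 or fall towards compound 3.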